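Trading an Aryl Group for a Short Hydroxyethyl Chain

The source may report more compounds than this note shows. Statements on the series, on what has been measured and on what is new or still open speak of the compounds shown alone.

Measured compounds:
compound 1, `CCCCCc1ccc(-c2cn(C[C@H](O)[C@H]3OC(=O)C(OCc4ccccc4)=C3OCc3ccccc3)nn2)cc1`: 9010 nM
compound 2, `COc1ccc(-c2cn(C/C=C3\OC(=O)C(OCc4ccccc4)=C3OCc3ccccc3)nn2)cc1`: 39100 nM
compound 3, `O=C1O/C(=C\Cn2cc(-c3cccc(O)c3)nn2)C(OCc2ccccc2)=C1OCc1ccccc1`: 27800 nM

All three share one core and differ only in the group carried on the five-membered aromatic ring with 3 nitrogen. In a functional assay on MCF7 cells (Homo sapiens) for antiproliferative activity, read by MTT assay, with a stated time of 72 h (a higher number here means a weaker inhibitor, a lower number a stronger inhibitor), compound 1 gives 9010 nM, the lowest number of the three; compound 3 lies a step beyond the scatter above it, and compound 2 a larger step above it still. For the measured compounds named here, the only one-place comparison among the measured compounds, a 1.4-fold lower number from compound 2 to compound 3 (0.15 log units; within the scatter), concerns a change of substituent on an aromatic ring and lies within the scatter.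

Compound 4, `O=C1O[C@H]([C@@H](O)Cn2cc(CCO)nn2)C(OCc2ccccc2)=C1OCc1ccccc1`, differs from compound 1 in a single place: 2-hydroxyethyl in place of 4-pentylphenyl on an aromatic carbon. Going by the values given here, no measured step shows what removing the whole aromatic group does; the one recorded step only swaps substituents on that group, so it bears on this change weakly at best. What the numbers do show is that compound 1, carrying the 4-pentylphenyl group, gives the lowest number, while compounds 2 and 3 with other aryl groups give higher ones. Losing the aryl group altogether is expected to move the number upward, with wide uncertainty. Compound 4 is therefore estimated at 30000 nM, from 8000 nM to 100000 nM. The expected step is a 3.3-fold higher number from compound 1 to compound 4 (0.52 log units; beyond the scatter).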

Compound 4, half-maximal inhibitory concentration: 63400 nM
For compound 4 the middle estimate is 2.1-fold (0.32 log units) below the measured one, and the stated range covers the measured number.
By their numbers in this assay, from the lowest: compound 1; then compounds 3, 2 and 4 (each within the scatter of the next, the first and the last beyond it).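

For the compounds shown here, this is the first measured step that removes the whole aromatic group rather than swapping a substituent on it: in this assay, putting 2-hydroxyethyl in place of 4-pentylphenyl on the aromatic carbon gives a 7.0-fold higher number from compound 1 to compound 4 (0.85 log units; beyond the scatter) in the same series. The group on this carbon therefore matters to the number, at least between these two compounds, so the position does not tolerate every replacement without change. The swap takes away 11 heavy atoms, including a six-membered aromatic ring, and brings in a short chain with a hydrogen-bond donor, all in one move, and no measurement shown explains why the number rises.

The compounds shown leave open whether the aromatic ring or its pentyl chain accounts for the step, a question that an unsubstituted phenyl group or a plain pentyl chain on the same carbon would help to separate. They also leave open what the hydroxyl of the 2-hydroxyethyl group contributes, which an ethyl group or a 2-aminoethyl chain in its place could test.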